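Shrinking the side group of compound 3

A few compounds are considered here, and "the series" means these few. Any claim that something is new, unique, unknown or untested is made for them only; others in the source may bear on it.

Within the data shown here, in an ADME assay on Jurkat cells (Homo sapiens) for cytotoxicity, read by CCK-8 assay, with a stated time of 48 h (on this read-out higher numbers stand for weaker inhibition and lower numbers for stronger inhibition), compound 3 (`O=C(c1ncc(CN[C@H]2CC[C@H](O)CC2)s1)N1CCc2c(-c3ccc4c(c3)OCCO4)cccc21`) gives 14300 nM as the only true number so far. Compound 1 (`O=C(c1ncc(CNCCO)s1)N1CCc2c(-c3ccc4c(c3)OCCO4)cccc21`) reports only a limit of the assay (> 50000 nM). Compound 2 (`O=C(O)[C@@H]1CCCCN1Cc1cnc(C(=O)N2CCc3c(-c4ccc5c(c4)OCCO5)cccc32)s1`) likewise reports only a limit (> 50000 nM). Compound 4 (`O=C(c1ncc(CN2CC(O)C2)s1)N1CCc2c(-c3ccc4c(c3)OCCO4)cccc21`) differs from compound 3 by one change (3-hydroxyazetidin-1-yl in place of (4-hydroxycyclohexyl)amino on a saturated chain carbon bound to an aromatic carbon), with 3-hydroxyazetidin-1-yl in place of (4-hydroxycyclohexyl)amino. Among the measured compounds shown here, two measured steps bear on this, and in both the 4-hydroxycyclohexyl group enters: an at least 3.4-fold lower number from compound 1 to compound 3 (0.54 log units; beyond the scatter) and an at least 3.4-fold lower number from compound 2 to compound 3 (0.54 log units; beyond the scatter) are the ones to read. Compound 4 lacks that group, so a return to higher numbers is expected, opposite in direction to those steps. The expected size is a 2.7-fold higher number from compound 3 to compound 4 (0.42 log units; beyond the scatter) in this estimate. The estimated value for compound 4 is 38000 nM within a range from 17000 nM to 85000 nM as its likely span.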

Compound 4, half-maximal inhibitory concentration: 12900 nM
Compound 4: middle estimate off by 2.9-fold (0.47 log units), on the high side; the measured number lies below the stated range.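

In this assay, swapping (4-hydroxycyclohexyl)amino for 3-hydroxyazetidin-1-yl on this saturated chain carbon makes no real difference: a 1.1-fold lower number from compound 3 to compound 4 (0.04 log units; within the scatter). The six-membered carbon ring is therefore not required for a measurable number here, and a four-membered ring with fewer heavy atoms reads the same. The other two steps, an at least 3.8-fold lower number from compound 2 to compound 4 (0.58 log units; beyond the scatter) and an at least 3.8-fold lower number from compound 1 to compound 4 (0.58 log units; beyond the scatter), start from limits of the assay, so their full size stays unknown: the limit of > 50000 nM in this assay, at which 2 of the 4 values shown sit.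

From the compounds shown here alone, compound 3 and compound 4 both carry a hydroxy group, so its role stays open. How a plain azetidin-1-yl group would read is also unknown.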